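The compounds below may be only part of what the source reports. "The series", "measured", "known", "first", "only" and "open" are said of these compounds alone.

Cytotoxicity notes on the series. Two compounds carry numbers in an ADME assay on RAW264.7 cells (Mus musculus) for cytotoxicity, read by MTT assay, with a stated time of 24 h; on this read-out lower numbers stand for higher toxicity in this test and higher numbers for lower toxicity in this test. Compound 1 `CC/C=C\CC1C(=O)C=CC1CC(=O)OC` gives 140 uM in this assay. Compound 2 `CC/C=C\C[C@H]1C(=O)C=C[C@H]1CC(=O)OCCCC` gives 31 uM in this assay, the lowest of the two numbers; the nearest number is that of compound 1, which lies beyond the scatter. For the measured compounds named here, no single-change step between the measured pair can be set out, so only the two values themselves are noted.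

Compound 3 `CC/C=C\C[C@H]1C(=O)C=C[C@H]1CC(=O)Oc1ccccc1` remains to be measured in this assay. Relative to compound 2 the change is phenyl in place of butyl on an oxygen next to a carbonyl group. Nothing measured bears directly on this exchange, so the expected step from butyl to phenyl is small and without clear direction, not beyond the scatter of the method. For compound 3 the expected value in this assay is 25 uM, within a range of 8 uM to 80 uM. The step of a 1.2-fold lower number from compound 2 to compound 3 (0.09 log units; within the scatter) is thus estimated as essentially flat.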

Compound 3, half-maximal toxic concentration: 158 uM
Beside the measured number, compound 3's estimate is 6.3-fold (0.80 log units) below it; measured number above the stated range.
By their numbers in this assay, from the lowest: compound 2; then compounds 1 and 3 (each within the scatter of the next).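

Phenyl in place of butyl on an oxygen next to a carbonyl group gives, in this assay, a 5.1-fold higher number from compound 2 to compound 3 (0.71 log units; beyond the scatter), the first single-change step measured in the series. This place on the shared core is therefore not silent: one exchange here moves the number beyond the scatter, towards lower toxicity in this test. No measurement at hand accounts for the size or direction of this step.

The compounds shown leave open whether the step follows the aromatic ring itself or the loss of the butyl chain, a question that a cyclohexyl or benzyl group on the same oxygen would address. As far as these compounds go, how a longer chain, a substituted phenyl or a free carboxylic acid at this place would read in this assay also remains open.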